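A few compounds are considered here, and "the series" means these few. Any claim that something is new, unique, unknown or untested is made for them only; others in the source may bear on it.

Measured compounds in a functional assay on LNCaP cells (Homo sapiens) for cytotoxicity, read by MTT assay, with a stated time of 48 h; a higher number here means a weaker inhibitor, a lower number a stronger inhibitor:
- compound 1, `Clc1ccc(-c2nc(-c3c[nH]c4ccccc34)co2)cc1`: 505000 nM
- compound 2, `Cn1cc(-c2coc(-c3ccc(Cl)cc3)n2)c2ccccc21`: 378000 nM

Compound 2 gives the lowest of the two numbers in this assay, with compound 1 nearest at a 1.3-fold lower number from compound 1 to compound 2 (0.13 log units; within the scatter); that step stays within the scatter, so the two compounds cannot be ordered on these numbers.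

Compound 3, `Clc1ccc(Cn2cc(-c3coc(-c4ccc(Cl)cc4)n3)c3ccccc32)cc1`, differs from compound 2 by 4-chlorophenyl in place of hydrogen on a saturated chain carbon bound to an aromatic nitrogen. For the measured compounds named here, no measured step changes this part of the structure: the only step, from compound 1 to compound 2, swaps hydrogen for methyl on the aromatic nitrogen and is within the scatter. Nothing here tells how a 4-chlorophenyl on that chain carbon would move this assay, so the expectation is broad. The step from compound 2 to compound 3 is estimated at a 1.9-fold lower number from compound 2 to compound 3 (0.28 log units; within the scatter), with no confident direction beyond the scatter. Compound 3 is estimated at 200000 nM, within a range of 50000 nM to 600000 nM.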

Compound 3, half-maximal inhibitory concentration: 182000 nM
Compound 3: the middle estimate sits 1.1-fold (0.04 log units) above what was measured, and the stated range covers the measured number.
By their numbers in this assay, from the lowest: compound 3; then compounds 2 and 1 (each within the scatter of the next).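

On the aromatic nitrogen, a substituent now gives a readable change in this assay: 4-chlorobenzyl in place of methyl gives a 2.1-fold lower number from compound 2 to compound 3 (0.32 log units; beyond the scatter) and 4-chlorobenzyl in place of hydrogen gives a 2.8-fold lower number from compound 1 to compound 3 (0.44 log units; beyond the scatter), whereas methyl in place of hydrogen alone gave no order. The position therefore accepts a group carrying a six-membered aromatic ring, and both steps run towards a lower number, though each is modest and compound 3 still reads 182000 nM in this assay. No measurement at hand bears on the reason for these steps.

The compounds shown leave open whether the step depends on the chlorine of the 4-chlorobenzyl or on the ring alone, a question that a plain benzyl on the aromatic nitrogen would separate. They also leave open how a longer chain ending in a phenyl ring or an amine would read at this position.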